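A Methyl on the Base: Expecting Compound 4

The source may hold more compounds than are shown below. What is called first, only, known or untested is meant among the compounds shown, and "the series" means these compounds.

Measured compounds:
compound 1, `CCS[C@@H]1[C@H](SCC)[C@@H](Cn2cc(-c3ccccc3)nn2)O[C@H]1n1ccc(=O)[nH]c1=O`, gives 8380 nM in a functional assay on HepG2 cells (Homo sapiens) for cytotoxicity, read by MTT assay, with a stated time of 72 h; on this read-out lower numbers stand for an effect already at smaller amounts and higher numbers for an effect only at larger amounts of compound.
compound 2, `CCS[C@@H]1[C@H](SCC)[C@@H](Cn2cc(-c3ccc(C)cc3)nn2)O[C@H]1n1ccc(=O)[nH]c1=O`, gives 19900 nM in this assay.
compound 3, `CCOC(=O)c1cn(C[C@H]2O[C@@H](n3ccc(=O)[nH]c3=O)[C@H](SCC)[C@@H]2SCC)nn1`, is reported only as a limit of the assay in this assay, namely >= 100000 nM.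

Compound 1 holds the lowest of the two plain numbers shown, and the single step that starts from it and ends in a number is a 2.4-fold higher number from compound 1 to compound 2 (0.38 log units; beyond the scatter). The other two steps, an at least 11-fold higher number from compound 1 to compound 3 (1.07 log units; beyond the scatter) and an at least 5.0-fold higher number from compound 2 to compound 3 (0.70 log units; beyond the scatter), end at the limit of >= 100000 nM in this assay, at which 1 of the 3 values shown sits.

Compound 4, `CCS[C@@H]1[C@H](SCC)[C@@H](Cn2cc(-c3ccccc3)nn2)O[C@H]1n1cc(C)c(=O)[nH]c1=O`, differs from compound 1 by methyl in place of hydrogen on an aromatic carbon. All three measured steps changed the group on the far side of the shared core, so none of them tests this position directly. The nearest comparison is the step from compound 1 to compound 2, where a methyl also entered an aromatic carbon and the number rose modestly. For compound 4 a small rise or no change beyond the scatter is therefore expected in this assay. Compound 4 is estimated at 11000 nM, between 4000 nM and 35000 nM. That estimate means a 1.3-fold higher number from compound 1 to compound 4 (0.12 log units; within the scatter).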

Compound 4, half-maximal effective concentration: 65000 nM
For compound 4 the middle estimate is 5.9-fold (0.77 log units) below the measured one; measured number above the stated range.
By their numbers in this assay, from the lowest: compound 1; then compound 2; then compound 4. At a limit, above all of these: compound 3.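

In this assay, among these compounds, methyl in place of hydrogen on an aromatic carbon of the six-membered aromatic ring with 2 nitrogen gives a 7.8-fold higher number from compound 1 to compound 4 (0.89 log units; beyond the scatter), so this ring, left unchanged in all the earlier compounds, is a place where one added carbon shifts the number beyond the scatter. The same exchange on the phenyl group at the far side of the shared core gave a 2.4-fold higher number from compound 1 to compound 2 (0.38 log units; beyond the scatter), and that earlier step alone could not tell what a methyl would do on the other ring, so a change has to be tested at each position and not carried over from another. Compound 4 still gives a plain number, whereas compound 3 alone sits at a limit of the assay: the limit of >= 100000 nM in this assay, at which 1 of the 4 values shown sits.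

Going by these compounds, it remains open whether an ethyl group, a chlorine atom or a hydroxymethyl group on the same ring carbon would move the number as the methyl does, or whether a different group there could lower it. On these data alone, it is also open whether the methyl would have a similar effect with 4-methylphenyl in place of phenyl, and the values shown give no reason for the rise.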